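Methyl for Ethynyl on the Ring Nitrogen of Compound 1

This account rests on a few compounds, and the source may have more. Where it says the series, first, only, none or still open, it means among the compounds named here.

Measured so far:
compound 1, `C#Cn1ccnc1C#Cc1ccc(OC)cc1`, 500 nM
compound 2, `C#Cn1ccnc1C#Cc1ccc(C(C)(C)C)cc1`, 2500 nM

In a functional assay on A549 cells (Homo sapiens) for cytotoxicity, read by resazurin assay, with a stated time of 72 h (a higher number here means a weaker inhibitor, a lower number a stronger inhibitor), compound 1 gives 500 nM, the lower of the two numbers; compound 2 gives 2500 nM. Going by the values given here, the only measured step, a 5.0-fold higher number from compound 1 to compound 2 (0.70 log units; beyond the scatter), comes from tert-butyl in place of methoxy on an aromatic carbon of the benzene end of the molecule.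

Compound 3 `COc1ccc(C#Cc2nccn2C)cc1` differs from compound 1 in another place: methyl in place of ethynyl on an aromatic nitrogen. Among the compounds with values here, nothing among the measured compounds touches this ring nitrogen, so the one known step cannot be carried over to it, and the size of the change to this assay is open. In the absence of any bearing step, no shift beyond the scatter is expected, with a wide range on either side.

For compound 3 the expected value in this assay is 700 nM, between 200 nM and 3000 nM. This estimate means a step of a 1.4-fold higher number from compound 1 to compound 3 (0.15 log units; within the scatter), which is expected to stay within the scatter.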

Compound 3, half-maximal inhibitory concentration: > 15000 nM
Compound 3 gave a limit, no number; the forecaster's own chance of this, stated with the estimate: 10%; middle value at least 21-fold (1.33 log units) from the limit.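

Going by these compounds alone, the ring nitrogen matters far more in this assay than the earlier compounds could show: methyl in place of ethynyl there gives an at least 30-fold higher number from compound 1 to compound 3 (1.47 log units; beyond the scatter), a larger change than a 5.0-fold higher number from compound 1 to compound 2 (0.70 log units; beyond the scatter) with tert-butyl in place of methoxy on an aromatic carbon. Compound 3 stands at a limit and not at a number: the limit of > 15000 nM in this assay, at which 1 of the 3 values shown sits. On these data alone, compound 1 and compound 2 both carry ethynyl on this nitrogen, so among the three compounds a measured number appears only with that group, and how far compound 3 lies past its limit is unknown.

As far as these compounds go, what an ethyl, a vinyl or a bare hydrogen on this nitrogen would give stays open, and with it whether the triple bond itself is what counts. Also open, from the compounds shown here alone, is whether the same exchange would act alike with tert-butyl in place of methoxy.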